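Swapping the pyridinyl of compound 1 for trifluorophenyl

The source may report more compounds than this note shows. Statements on the series, on what has been measured and on what is new or still open speak of the compounds shown alone.

Measured so far:
compound 1, `O=C1CCCC2=C1C(c1ccc(F)cc1Cl)N=C(c1cccnc1)N2`, in an ADME assay on HepG2 2.2.15 cells (Homo sapiens) for cytotoxicity; a higher number here means a weaker inhibitor, a lower number a stronger inhibitor: 82800 nM
compound 2, `O=C1CCCC2=C1C(c1ccccc1Cl)N=C(c1cccnc1)N2`, in this assay: 1120000 nM

Compound 1 holds the lowest of the two numbers. Its nearest neighbour is compound 2, reached by hydrogen in place of fluoro on an aromatic carbon, a change that gave a 14-fold higher number from compound 1 to compound 2 (1.13 log units; beyond the scatter).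

Compound 3, `O=C1CCCC2=C1C(c1ccc(F)cc1Cl)N=C(c1c(F)cc(F)cc1F)N2`, is not yet measured. It differs from compound 1 by 2,4,6-trifluorophenyl in place of pyridin-3-yl on a carbon with a double bond to nitrogen. No measured step bears on this exchange: the single step, from compound 1 to compound 2, alters the 2-chloro-4-fluorophenyl group, which compound 3 keeps unchanged, and nothing shown touches the group on the carbon with a double bond to nitrogen. Among the compounds with values here, the only guide is that compound 1 gives 82800 nM in this assay, and a change elsewhere in the molecule moved the number by a large amount, so a wide range is appropriate.

Compound 3 is therefore expected to land near compound 1, at an estimated 60000 nM with a range of 15000 nM to 250000 nM. That estimate corresponds to an expected 1.4-fold lower number from compound 1 to compound 3 (0.14 log units; within the scatter), with no direction asserted beyond the scatter.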

Compound 3, half-maximal inhibitory concentration: 123000 nM
Compound 3: middle estimate off by 2.1-fold (0.31 log units), on the low side, within the range that was stated.
By their numbers in this assay, from the lowest: compounds 1 and 3 (each within the scatter of the next); then compound 2.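

In this assay, the exchange of pyridin-3-yl for 2,4,6-trifluorophenyl on the carbon with a double bond to nitrogen gave a 1.5-fold higher number from compound 1 to compound 3 (0.17 log units; within the scatter), so this pair cannot be told apart by its numbers. It is the only pair shown that speaks to this position, and on the core of compound 1 the ring nitrogen, with its hydrogen-bond acceptor, could give way to a carbon-only ring carrying three fluorine atoms without a step beyond the scatter, whereas the change at the 2-chloro-4-fluorophenyl group, a 14-fold higher number from compound 1 to compound 2 (1.13 log units; beyond the scatter), lies beyond it. No measurement is at hand that would account for either outcome.

Going by these compounds, the two groups seen at this position are both six-membered aromatic rings, so it stays open how this assay would read for a non-aromatic group there, such as a morpholine, a butyl chain or a ring bearing a carboxylic acid. On these data alone, it is also open whether hydrogen in place of fluoro on the 2-chloro-4-fluorophenyl group would give a step of similar size with 2,4,6-trifluorophenyl in place.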